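Cutting the benzyl ester back to the free acid

The source may hold more compounds than are shown below. What is called first, only, known or untested is meant among the compounds shown, and "the series" means these compounds.

Measured so far:
- compound 1, `C[C@H](NC(=O)CN(c1nc(Cl)nc2[nH]cnc12)C1CC1)C(=O)OCc1ccccc1`: 23%
- compound 2, `O=C(CN(c1nc(Cl)nc2[nH]cnc12)C1CC1)NCC(=O)OCc1ccccc1`: 18%
- compound 3, `C[C@@H](O)[C@H](NC(=O)CN(c1nc(Cl)nc2[nH]cnc12)C1CC1)C(=O)OCc1ccccc1`: 12.8%

All three compounds share one core and were tested in a functional assay on the whole organism (Tail, strain ICR) with Mus musculus as the target, in the tail flick test, with a stated time of 150 min, at a dose of 25 umol/kg by the oral route; a higher number here means a stronger effect of the compound at the dose given, a lower number a weaker effect. Among the measured compounds shown here, compound 2 stands second highest of the three numbers, but the step of a number 5 percentage points lower from compound 1 to compound 2 (within the scatter) and the step of a number 5.2 percentage points lower from compound 2 to compound 3 (within the scatter) both lie within the scatter, so the three are not clearly separated; only the step of a number 10.2 percentage points lower from compound 1 to compound 3 (beyond the scatter) is beyond it, and it is modest.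

The unmeasured compound 4, `O=C(O)CNC(=O)CN(c1nc(Cl)nc2[nH]cnc12)C1CC1`, differs from compound 2 in one place:

hydrogen in place of benzyl on an oxygen next to a carbonyl group

For the measured compounds named here, none of the measured steps touches this position. Every step seen so far changes the group on the saturated chain carbon bound to an amide-type nitrogen and a carbonyl carbon, and all of those steps stayed small. They therefore say nothing direct about what happens when benzyl is replaced by hydrogen on an oxygen next to a carbonyl group.

Going by the values given here, with no comparable step to lean on, the expectation for compound 4 is simply a value near that of compound 2, with the step of a number 3 percentage points lower from compound 2 to compound 4 (within the scatter) expected to stay within the scatter but with a wide range. Compound 4 is estimated at 15%, between 0% and 32%.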

Compound 4, a percentage reported as activity, at one dose (the size of the read-out at that dose, not a potency): 9.08%
Estimate against measurement, compound 4: 5.9 percentage points above, and the stated range covers the measured number.
By their numbers in this assay, from the lowest: compounds 4, 3, 2 and 1 (each within the scatter of the next, the first and the last beyond it).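

Among the compounds shown here, this is the first step at the benzyl ester, and in this assay hydrogen in place of benzyl on an oxygen next to a carbonyl group gives a number 8.9 percentage points lower from compound 2 to compound 4 (within the scatter). The step therefore stays within the usual variation of this read-out, even though it removes a whole benzyl group, with its seven carbon atoms and its six-membered aromatic ring, and turns benzyloxy into hydroxy. Nothing available here explains this result or shows what happens to either compound inside the animal.

The compounds shown leave open whether a small group on this oxygen, such as methyl or ethyl, would read like benzyl or like hydrogen, and whether an amide formed with an amine at this carbonyl would fit the same picture. Also open, from the compounds shown here alone, is what the same swap of benzyl for hydrogen does when the saturated chain carbon carries the methyl of compound 1 or the 1-hydroxyethyl of compound 3.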